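Cyano for fluoro on the pendant aryl group

The source may report more compounds than this note shows. Statements on the series, on what has been measured and on what is new or still open speak of the compounds shown alone.

compound 1 `O=[N+]([O-])c1ccc(CN2CCC(n3cc(CC(OCc4cc(-c5ccc(F)cc5)no4)c4ccc(Br)cc4)nn3)CC2)cc1` 7000 nM
compound 2 `O=[N+]([O-])c1ccc(CN2CCC(n3cc(CC(OCc4cc(-c5cccc(F)c5)no4)c4ccc(Br)cc4)nn3)CC2)cc1` 8000 nM

Of the compounds shown here, two have been measured in a functional assay on MCF7 cells (Homo sapiens) for cytotoxicity, with a stated time of 48 h; on this read-out lower numbers stand for stronger inhibition and higher numbers for weaker inhibition. In this assay compound 1 gives 7000 nM. In this assay compound 2 gives 8000 nM. Among the measured compounds shown here, the only step so far, a 1.1-fold higher number from compound 1 to compound 2 (0.06 log units; within the scatter), moves the fluoro from one aromatic position to another and leaves the number essentially where it was. Compound 2 and compound 1 therefore sit within the scatter of each other; on the numbers shown compound 2 is not separated from compound 1.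

Compound 3 `N#Cc1cccc(-c2cc(COC(Cc3cn(C4CCN(Cc5ccc([N+](=O)[O-])cc5)CC4)nn3)c3ccc(Br)cc3)on2)c1` differs from compound 2 by cyano in place of fluoro on an aromatic carbon. For the measured compounds named here, no measured step exchanges fluoro for cyano, so nothing bears directly on this change; the one step available, from compound 1 to compound 2, was within the scatter. The expectation for this assay is a step of no change at the digits printed from compound 2 to compound 3 (within the scatter), with no change beyond the scatter. Compound 3 is estimated at 8000 nM, within 3000 nM to 25000 nM.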

Compound 3, half-maximal inhibitory concentration: 2000 nM
The estimate for compound 3 lay 4.0-fold (0.60 log units) above the measured number; the measured number lies below the stated range.
By their numbers in this assay, from the lowest: compound 3; then compounds 1 and 2 (each within the scatter of the next).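

In this assay, the 3-fluorophenyl to 3-cyanophenyl exchange gives a 4.0-fold lower number from compound 2 to compound 3 (0.60 log units; beyond the scatter) at this place, on an aromatic carbon meta to a large group, so the aryl group responds to the identity of its substituent, whereas relocating the fluoro gave only a 1.1-fold higher number from compound 1 to compound 2 (0.06 log units; within the scatter) within the scatter. Replacing 4-fluorophenyl with 3-cyanophenyl gives a 3.5-fold lower number from compound 1 to compound 3 (0.54 log units; beyond the scatter) in the same direction, although this step changes both the group and its place. Nothing available bears on the reason for the difference between cyano and fluoro.

Going by these compounds, it remains open whether the stronger inhibition is specific to cyano or also extends to other groups at this place, such as an amine, a carboxylic acid or a methoxy group. On these data alone, the effect of 4-cyanophenyl also remains open, so the contribution of position to the cyano result cannot be separated.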